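The source may hold more compounds than are shown below. What is called first, only, known or untested is meant among the compounds shown, and "the series" means these compounds.

Of the compounds shown here, two have been measured so far in a functional assay on HT-29 cells (Homo sapiens) for cytotoxicity, read by MTT assay, with a stated time of 72 h (on this read-out lower numbers stand for stronger inhibition and higher numbers for weaker inhibition), and they sit well apart. Compound 1 (`O=C(CN1CCN(c2nnc(Cc3ccccc3)c3ccccc23)CC1)Nc1c(F)cccc1F`) gives 19700 nM and holds the higher of the two numbers, while compound 2 (`O=C(CN1CCN(c2nnc(Cc3ccncc3)c3ccccc23)CC1)Nc1cccc(Br)c1`) gives 1350 nM as the lower one, a gap beyond the usual scatter. Compound 3 (`Cc1ccccc1NC(=O)CN1CCN(c2nnc(Cc3ccccc3)c3ccccc23)CC1`) keeps the core of compound 1 and carries 2-methylphenyl in place of 2,6-difluorophenyl on an amide-type nitrogen. Within the data shown here, no measured pair differing in a single place is available, so this change has no direct precedent in the data. The expected step (a 1.6-fold lower number from compound 1 to compound 3 (0.22 log units; within the scatter)) stays within the scatter, with a slight lean towards a lower number. Compound 3 is estimated at 12000 nM in this assay with an expected range from 4000 nM to 35000 nM around that figure.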

Compound 3, half-maximal inhibitory concentration: 113000 nM
Estimate against measurement, compound 3: 9.4-fold (0.97 log units) below; the whole stated range lies below it.
By their numbers in this assay, from the lowest: compound 2; then compound 1; then compound 3.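

In this assay, replacing 2,6-difluorophenyl with 2-methylphenyl on the amide-type nitrogen brings a 5.7-fold higher number from compound 1 to compound 3 (0.76 log units; beyond the scatter), a shift beyond the scatter towards weaker inhibition. This single-place change therefore shows that the group on this nitrogen matters to the read-out, even though the two groups are close in size by heavy-atom count and neither adds a hydrogen-bond donor or acceptor. Nothing available here accounts for the shift.

Among these compounds, the one pair cannot tell whether the change follows from losing the two fluorine atoms or from gaining the methyl group. An unsubstituted phenyl or a 2-fluorophenyl on the same nitrogen would separate those two parts, and an amine or a carboxylic acid on the ring remains an open question.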